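The compounds below may be only part of what the source reports. "The series", "measured", "known", "first", "only" and "open" are said of these compounds alone.

Measured in a functional assay on PC-3 cells (Homo sapiens) for antiproliferative activity, read by MTT assay, with a stated time of 48 h; on this read-out higher numbers stand for weaker inhibition and lower numbers for stronger inhibition:
- Compound 1 `C#CCCOC(=O)c1ccc(C(CC)(CC)c2ccc(OCCC(O)(CC)CC)c(C)c2)n1CC`: > 50000 nM, which is a limit.
- Compound 2 `CCn1c(C(=O)Nc2cccc(C(F)(F)F)c2)ccc1C(CC)(CC)c1ccc(OCCC(O)(CC)CC)c(C)c1`: 23800 nM
- Compound 3 `CCn1c(C(=O)N(C)CC(=O)O)ccc1C(CC)(CC)c1ccc(OCCC(O)(CC)CC)c(C)c1`: 2250 nM

Compound 3 has the lowest number of the series, and compound 2 is its nearest neighbour. Compound 4 `CCn1c(C(=O)NC(CO)CCO)ccc1C(CC)(CC)c1ccc(OCCC(O)(CC)CC)c(C)c1` changes the group on the carbonyl carbon: a group of 7 heavy atoms (4 carbon, 1 nitrogen, 2 oxygen; no ring) in place of a group of 6 heavy atoms (3 carbon, 1 nitrogen, 2 oxygen; no ring), on a carbonyl carbon. All three measured steps changed that same group. Two were large, an at least 22-fold lower number from compound 1 to compound 3 (1.34 log units; beyond the scatter) and an 11-fold lower number from compound 2 to compound 3 (1.02 log units; beyond the scatter), while an at least 2.1-fold lower number from compound 1 to compound 2 (0.32 log units; beyond the scatter) was smaller, so a step beyond the scatter is plausible here too. Since compound 3 already sits at 2250 nM, a moderate rise in this assay is expected rather than a further fall. The expected change is a 2.4-fold higher number from compound 3 to compound 4 (0.39 log units; beyond the scatter). The estimated value for compound 4 is 5500 nM, within a range of 1500 nM to 22000 nM.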

Compound 4, half-maximal inhibitory concentration: 8760 nM
Beside the measured number, compound 4's estimate is 1.6-fold (0.20 log units) below it; low and high end bracket the measured number.
By their numbers in this assay, from the lowest: compound 3; then compound 4; then compound 2. At a limit, above all of these: compound 1.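

In this assay, placing the open-chain group of compound 4 on the carbonyl carbon in place of (carboxymethyl)(methyl)amino gives a 3.9-fold higher number from compound 3 to compound 4 (0.59 log units; beyond the scatter), so the gain seen with that earlier group is not fully kept. On the amide-type nitrogen, 3-hydroxy-1-(hydroxymethyl)propyl still improves on 3-(trifluoromethyl)phenyl, with a 2.7-fold lower number from compound 2 to compound 4 (0.43 log units; beyond the scatter). Against the (but-3-yn-1-yl)oxy group, an at least 5.7-fold lower number from compound 1 to compound 4 (0.75 log units; beyond the scatter) is only a bound, resting on a limit: the limit of > 50000 nM in this assay, at which 1 of the 4 values shown sits.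

Going by these compounds, whether a longer chain ending in a carboxylic acid would go lower than compound 3 stays open. Also open, on these data alone, is which hydroxyl group of compound 4 matters.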